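Swapping an Aryl Amide for a Pyrrolidine Chain

A few compounds are considered here, and "the series" means these few. Any claim that something is new, unique, unknown or untested is made for them only; others in the source may bear on it.

Of the compounds shown here, three sharing one core have been measured in an assay on isolated protein for inhibition of glutathione S-transferase P (Homo sapiens), with a stated time of 10 min; on this read-out lower numbers stand for stronger inhibition and higher numbers for weaker inhibition. Compound 1 `O=C(O)CCC(=O)OCCCCCCSc1ccc([N+](=O)[O-])c2nonc12` gives 530 nM. Compound 2 `O=C(CCC(=O)OCCCCCCSc1ccc([N+](=O)[O-])c2nonc12)Nc1cccc(Cl)c1` gives 28800 nM, and compound 3 `COc1ccc(NC(=O)CCC(=O)OCCCCCCSc2ccc([N+](=O)[O-])c3nonc23)cc1` gives 420 nM. Compound 3 has the lowest number of the three, but its gap to compound 1 is within the scatter, so the two cannot be ordered; only compound 2 stands clearly apart, as seen in a 69-fold lower number from compound 2 to compound 3 (1.84 log units; beyond the scatter) and a 54-fold higher number from compound 1 to compound 2 (1.74 log units; beyond the scatter), while a 1.3-fold lower number from compound 1 to compound 3 (0.10 log units; within the scatter) shows no real change.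

Compound 4 `O=C(CCC(=O)OCCCCCCSc1ccc([N+](=O)[O-])c2nonc12)NCCN1CCCC1` differs from compound 3 in one place: 2-(pyrrolidin-1-yl)ethyl in place of 4-methoxyphenyl on an amide-type nitrogen.

Which measured steps speak to this? For the measured compounds named here, only one step changes the group on the amide-type nitrogen, the large one from compound 2 to compound 3, and it shows that this position can swing the result strongly between two aromatic groups. Going by the values given here, no measured step exchanges an aromatic group for a non-aromatic chain, so the direction is open. Given that the closest precedents are one neutral and one very large step, the number for compound 4 is expected to sit at 1500 nM, with a wide range from 300 nM to 12000 nM, which would mean an estimated step of a 3.6-fold higher number from compound 3 to compound 4 (0.55 log units; beyond the scatter) in this assay.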

Compound 4, half-maximal inhibitory concentration: 460 nM
Estimate against measurement, compound 4: 3.3-fold (0.51 log units) above; the range from low to high includes it.
By their numbers in this assay, from the lowest: compounds 3, 4 and 1 (each within the scatter of the next); then compound 2.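

This result shows that, in this assay, an aromatic ring on the amide-type nitrogen is not required for a number in the range of compound 3: with 2-(pyrrolidin-1-yl)ethyl in place of 4-methoxyphenyl, the result is a 1.1-fold higher number from compound 3 to compound 4 (0.04 log units; within the scatter). Compound 4 also cannot be told apart from the free acid, as a 1.2-fold lower number from compound 1 to compound 4 (0.06 log units; within the scatter) shows, so the hydroxy compound and both amides with these two groups now form one cluster. Against that cluster, only the amide with 3-chlorophenyl stands apart, as seen in a 63-fold lower number from compound 2 to compound 4 (1.80 log units; beyond the scatter), which shows that the gap around compound 2 appears against a non-aromatic chain as well as against an aromatic group.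

No measurement on hand accounts for the gap around compound 2. The compounds shown leave open whether this tolerance extends to a 2-(morpholin-4-yl)ethyl group or a longer chain carrying the pyrrolidine, and whether an unsubstituted phenyl or a 4-chlorophenyl group on the same nitrogen would stay with the cluster or move toward compound 2.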